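The compounds below may be only part of what the source reports. "The series", "measured", "known", "first", "only" and "open" are said of these compounds alone.

The measured compounds:
Compound 1 `CC(C)=CC[C@@H](OC[C@@H](C)O)C1=CC(=O)c2c(O)ccc(O)c2C1=O` gives 22500 nM in a functional assay on HeLa cells (Homo sapiens) for cytotoxicity, read by MTT assay; on this read-out higher numbers stand for weaker inhibition and lower numbers for stronger inhibition.
Compound 2 `CC(C)=CC[C@@H](OC(=O)C1CCOC1)C1=CC(=O)c2c(O)ccc(O)c2C1=O` gives 73500 nM in this assay.
Compound 3 `CC(C)=CC[C@@H](OC(=O)C1CCCCO1)C1=CC(=O)c2c(O)ccc(O)c2C1=O` reaches only a limit of the assay, > 100000 nM in this assay.

Compound 3 therefore stands at the weak end of the numbers shown: it is the one compound sitting at the limit of > 100000 nM in this assay, at which 1 of the 3 values shown sits, and no number is known for it. The steps reaching it were an at least 4.4-fold higher number from compound 1 to compound 3 (0.64 log units; beyond the scatter) and an at least 1.3-fold higher number from compound 2 to compound 3 (0.13 log units; that floor lies within the scatter), the latter with a floor inside the scatter.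

Compound 4 `CC(C)=CC[C@@H](OC(=O)CC(C)(O)C(C)C)C1=CC(=O)c2c(O)ccc(O)c2C1=O` differs from compound 3 in one place: 2-hydroxy-2,3-dimethylbutyl in place of oxan-2-yl on a carbonyl carbon. For the measured compounds named here, no measured step alters the group on the carbonyl carbon in just this way. Compound 1, the only compound carrying a hydroxyl in its side chain, gives the lowest number shown, while both compounds with a carbonyl on the oxygen give higher ones, as a 3.3-fold higher number from compound 1 to compound 2 (0.51 log units; beyond the scatter) shows. Compound 4 keeps the carbonyl but brings a hydroxyl back, so a modest step down from compound 3 is expected, with the outcome uncertain as compound 3 holds only a limit. Compound 4 is estimated at 70000 nM, between 25000 nM and 200000 nM, which would mean a step of an at least 1.4-fold lower number from compound 3 to compound 4 (0.15 log units; that floor lies within the scatter).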

Compound 4, half-maximal inhibitory concentration: 27700 nM
For compound 4 the middle estimate is 2.5-fold (0.40 log units) above the measured one; the range from low to high includes it.
By their numbers in this assay, from the lowest: compounds 1 and 4 (each within the scatter of the next); then compound 2. At a limit, above all of these: compound 3.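

On the carbonyl carbon, the open 2-hydroxy-2,3-dimethylbutyl chain, which carries a hydrogen-bond donor, gives a lower number in this assay than either ring shown there: an at least 3.6-fold lower number from compound 3 to compound 4 (0.55 log units; beyond the scatter) and a 2.7-fold lower number from compound 2 to compound 4 (0.42 log units; beyond the scatter). The first of these steps is only a floor, since compound 3 stands at a limit of the assay: the limit of > 100000 nM in this assay, at which 1 of the 4 values shown sits. The carbonyl on the oxygen does not by itself raise the number, as compound 4 keeps it and still shows a 1.2-fold higher number from compound 1 to compound 4 (0.09 log units; within the scatter).

Compound 4 loses the ring and gains the hydroxyl in the same change, and the two cannot be separated here. The compounds shown also leave open how an amine or a carboxylic acid on this side chain would read in this assay.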